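The source may hold more compounds than are shown below. What is called first, only, known or untested is meant among the compounds shown, and "the series" means these compounds.

Compound 1, `Cc1cc(N2CCN(C)CC2)cn2c(CSCCc3ccccc3)cnc12`, gives 20 ug/mL in an ADME assay on HEL cells (Homo sapiens) for cytotoxicity, with a stated time of 3 days; on this read-out higher numbers stand for lower toxicity in this test and lower numbers for higher toxicity in this test.
Compound 2, `Cc1cc(-n2ccc3ccccc32)cn2c(CSCCc3ccccc3)cnc12`, gives only the limit > 20 ug/mL in this assay.
Compound 3, `Cc1cc(N2CCCC2=O)c2ncc(CSCCc3ccccc3)n2c1`, gives 20 ug/mL in this assay.

Compound 3 stands level with compound 1 at the digits shown, and the two lie within the scatter of each other. The value of compound 2 is a limit of the assay, not a number, as the limit of > 20 ug/mL in this assay, at which 1 of the 3 values shown sits, records. Compound 4, `Cc1cc(Sc2ccc(Cl)cc2)c2ncc(CSCCc3ccccc3)n2c1`, has not been measured. It differs from compound 3 in one place: (4-chlorophenyl)sulfanyl in place of 2-oxopyrrolidin-1-yl on an aromatic carbon. Within the data shown here, the single measured step that bears on this is a number no lower from compound 1 to compound 2 (the limit leaves the size open), where an aromatic group replaced a saturated ring on an aromatic carbon and the number did not fall, though its size stays open. From this the account expects no step beyond the scatter for compound 4, with no change at the digits printed from compound 3 to compound 4 (within the scatter) as the expected change. For compound 4 the estimate in this assay is 20 ug/mL, expected to fall between 10 ug/mL and 40 ug/mL.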

Compound 4, minimum cytotoxic concentration: 4 ug/mL
Compound 4: middle estimate off by 5.0-fold (0.70 log units), on the high side; measured number outside the range, below it.
By their numbers in this assay, from the lowest: compound 4; then compounds 1 and 3 (each within the scatter of the next).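

In this assay, the exchange on this aromatic carbon, ortho to a fused ring, gives a 5.0-fold lower number from compound 3 to compound 4 (0.70 log units; beyond the scatter), toward higher toxicity in this test. Among these compounds, this is the first step in the set whose size can be read, and it shows that the group at this place can move the read-out. The earlier step to an aromatic group ended in a limit and not a number, while here the entry of (4-chlorophenyl)sulfanyl brings a clear fall, and nothing measured accounts for it.

The compounds shown leave open whether the sulfur link or the 4-chlorophenyl ring carries this step, as the two enter together. A plain phenylsulfanyl group, or a 4-chlorophenoxy group at the same carbon, would separate the two.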